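This account rests on a few compounds, and the source may have more. Where it says the series, first, only, none or still open, it means among the compounds named here.

Measured in a functional assay on DU-145 cells (Homo sapiens) for inhibition, read by trypan blue exclusion, with a stated time of 96 h; on this read-out lower numbers stand for stronger inhibition of growth and higher numbers for weaker inhibition of growth:
- Compound 1 `O=C(/C(=C\c1c(O)cc(O)cc1O)Sc1ccc(Br)cc1)c1ccc(Cl)cc1`: 50000 nM
- Compound 2 `CN(C)c1ccc(/C=C(/SCc2ccc(Cl)cc2Cl)C(=O)c2ccc(Cl)cc2)cc1`: 50000 nM

Level with compound 1 at the digits shown, compound 2 gives 50000 nM, and the two values cannot be told apart. Among the compounds with values here, this leaves no gradient to follow, and no step between measured compounds that differ in one place is available.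

Compound 3 `O=C(/C(=C\c1c(O)cc(O)cc1O)SCc1ccc(Cl)cc1Cl)c1ccc(Cl)cc1` has not yet been measured. It keeps the rest of compound 2 but carries 2,4,6-trihydroxyphenyl in place of 4-(dimethylamino)phenyl on a double-bonded chain carbon bound to a double-bonded chain carbon.

The entering group is already present in compound 1, which gives 50000 nM, so the data offer no sign that this group alone brings a large gain. Compound 1 also differs from compound 3 elsewhere, however, and no measurement isolates this exchange.

In this assay, the estimated step is a 1.7-fold lower number from compound 2 to compound 3 (0.22 log units; within the scatter), a small one leaning towards stronger inhibition of growth. For compound 3 the estimate is 30000 nM, with an expected range from 5000 nM to 60000 nM.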

Compound 3, concentration for 50% growth inhibition: 25000 nM
Compound 3: middle estimate off by 1.2-fold (0.08 log units), on the high side; measured number inside the range.
By their numbers in this assay, from the lowest: compounds 3, 1 and 2 (each within the scatter of the next).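

In this assay, within the data shown here, putting 2,4,6-trihydroxyphenyl in place of 4-(dimethylamino)phenyl on a double-bonded chain carbon bound to a double-bonded chain carbon gives a 2.0-fold lower number from compound 2 to compound 3 (0.30 log units; within the scatter), the first comparison at this position in which only one place differs. At this position, a group with 3 hydrogen-bond donors and 3 hydrogen-bond acceptors therefore stands in for one with 0 donors and 1 acceptor without a difference that can be told from the scatter, while 2,4-dichlorobenzyl in place of 4-bromophenyl on a sulfur gives a 2.0-fold lower number from compound 1 to compound 3 (0.30 log units; within the scatter), which also stays within the scatter. No separate information bears on these results.

The three compounds show only these two exchanges, both starting from or arriving at compound 3, so they say nothing about how other groups would behave in either place. From the compounds shown here alone, it remains open whether a carboxylic acid or a morpholine on the double-bonded chain carbon, or a longer alkyl chain on the sulfur, would give growth-inhibition numbers that stand clearly apart from these.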